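The source may hold more compounds than are shown below. What is called first, only, known or untested is meant among the compounds shown, and "the series" means these compounds.

Compound 1 `O=c1[nH]c(=O)n([C@H]2C[C@H](O)[C@@H](CO)O2)cc1C#CC#Cc1ccccn1` — 1500 nM
Compound 2 `Nc1ccc(C#CC#Cc2cn([C@H]3C[C@H](O)[C@@H](CO)O3)c(=O)[nH]c2=O)cc1` — reported only as a limit, > 100000 nM

For the measured compounds named here, in an ADME assay on HEL cells (Homo sapiens), read by cell counting, with a stated time of 3 days (a lower number here means that less compound is tolerated, a higher number that more compound is tolerated), compound 1 gives 1500 nM, the only plain number among the two values shown. For compound 2 this assay reports a limit, > 100000 nM. One of the two values sits at that limit (the limit of > 100000 nM in this assay, at which 1 of the 2 values shown sits). The measured step is an at least 66-fold higher number from compound 1 to compound 2 (1.82 log units; beyond the scatter), where 4-aminophenyl replaces pyridin-2-yl on a triple-bonded carbon.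

Compound 3 `O=c1[nH]c(=O)n([C@H]2C[C@H](O)[C@@H](CO)O2)cc1C#CC#CCC1CCCC1` differs from compound 1 by cyclopentylmethyl in place of pyridin-2-yl on a triple-bonded carbon. Going by the values given here, the one measured step concerns a different group entering at the same place, so it bears only loosely here. Compound 3 is expected at 5000 nM, within 1000 nM to 50000 nM, an estimated step of a 3.3-fold higher number from compound 1 to compound 3 (0.52 log units; beyond the scatter).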

Compound 3, half-maximal cytotoxic concentration: 89000 nM
The estimate for compound 3 lay 18-fold (1.25 log units) below the measured number, outside the stated range (above it).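

In this assay, cyclopentylmethyl gives a 59-fold higher number from compound 1 to compound 3 (1.77 log units; beyond the scatter), so a large rise at this place does not require an aromatic ring or an amine in the entering group. The value of compound 2, > 100000 nM, is a limit. The step of an at least 1.1-fold lower number from compound 2 to compound 3 (0.05 log units; that floor lies within the scatter) has a floor within the scatter, so no order can be read between these two compounds.

As far as these compounds go, it remains open whether a plain phenyl or pyridin-3-yl group would sit nearer compound 1 or compound 3. Any higher values at this place remain bounded by the assay's upper limit: the limit of > 100000 nM in this assay, at which 1 of the 3 values shown sits.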